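Sulfonyl-piperidine series: cytotoxicity limits and an unmeasured phenyl variant

A few compounds are considered here, and "the series" means these few. Any claim that something is new, unique, unknown or untested is made for them only; others in the source may bear on it.

The shared core is seen in compound 1 `CC1CCN(C2CCN(S(=O)(=O)c3nccn3C)CC2)CC1`. In an ADME assay on HCT-116 cells (Homo sapiens) for cytotoxicity, read by CellTiter-Glo, with a stated time of 72 h (a lower number here means a stronger inhibitor, a higher number a weaker inhibitor), compound 1 reaches only a limit of the assay, > 10000 nM, not a number. Compound 2 `COc1ccc(NS(=O)(=O)N2CCC(N3CCC(C)CC3)CC2)cc1` also stops at a limit in this assay, > 5000 nM. Compound 3 `Cc1cc(C)c(S(=O)(=O)N2CCC(N3CCC(C(C)C)CC3)CC2)c(C)c1` likewise gives only a limit, > 5000 nM. Compound 1 therefore sits at the less stringent of the two limits recorded: the limit of > 10000 nM in this assay, at which 1 of the 3 values shown sits, while the other two compounds sit at the limit of > 5000 nM in this assay, at which 2 of the 3 values shown sit. None of the three measured compounds differ from one another in a single place, so no measured step in this assay is available, and no direction of change can be read from the numbers shown.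

Compound 4 `CCc1ccc(S(=O)(=O)N2CCC(N3CCC(C)CC3)CC2)cc1` has not yet been measured. It differs from compound 1 in one place: 4-ethylphenyl in place of 1-methyl-1H-imidazol-2-yl on a sulfonyl sulfur. With every value in the series a limit, the expectation for compound 4 is a further limit rather than a number, and no shift beyond the scatter is expected in either direction. Compound 4 is estimated at 20000 nM, with a range from 5000 nM to 80000 nM. The expected step that the limit leaves unreadable from compound 1 to compound 4 is thus essentially none against the limit already recorded.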

Compound 4, half-maximal inhibitory concentration: > 5000 nM
Compound 4 ended at the assay's limit (the forecaster's own chance of this, stated with the estimate: 80%); the middle value lies beyond the limit too.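

Compound 1 and compound 4 both stop at limits of this assay, not numbers, so no step between them can be read: the limit of > 5000 nM in this assay, at which 3 of the 4 values shown sit.

The compounds shown leave open how 4-ethylphenyl compares with 1-methyl-1H-imidazol-2-yl on a sulfonyl sulfur, and whether any compound on the shared core gives a numerical half-maximal inhibitory concentration in this assay.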